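Side-chain replacement on the amine carbon of the series

This account rests on a few compounds, and the source may have more. Where it says the series, first, only, none or still open, it means among the compounds named here.

Among the measured compounds shown here, compound 2 `CC(C)(N)CCCN(C[C@H]1Cc2ccccc2CN1)[C@H]1CCCc2cccnc21` is the only member with a number in a functional assay on cells for antagonist activity at C-X-C chemokine receptor type 4 (Homo sapiens), read by fluorescence and calcium flux, with stated times of 25 min and 90 s; a higher number here means a weaker inhibitor, a lower number a stronger inhibitor; in that assay compound 2 gives 24.6 nM. Compound 1 `CC(C)(CCN)CN(C[C@H]1Cc2ccccc2CN1)[C@H]1CCCc2cccnc21` gives > 33300 nM in this assay, which is a limit of the assay and not a number (the limit of > 33300 nM in this assay, at which 1 of the 2 values shown sits). For the measured compounds named here, the one measured step, an at least 1300-fold lower number from compound 1 to compound 2 (3.13 log units; beyond the scatter), shows that an exchange of the group on the saturated chain carbon bound to the amine nitrogen can move the read-out very far.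

Compound 3 `C(=C/CN(C[C@H]1Cc2ccccc2CN1)[C@H]1CCCc2cccnc21)\CNCC1CCOCC1` carries a further exchange at the same place: a group of 11 heavy atoms (9 carbon, 1 nitrogen, 1 oxygen; one six-membered non-aromatic ring with 1 hetero atom) in place of a group of 6 heavy atoms (5 carbon, 1 nitrogen; no ring), on a saturated chain carbon bound to an amine nitrogen. Going by the values given here, only the step from compound 1 to compound 2 bears on it, and that step was large, so a step beyond the scatter is expected here as well; the direction is uncertain, and the new group, with a double bond outside aromatic rings and a six-membered non-aromatic ring with one hetero atom, is unlike either group measured so far. The estimated step from compound 2 to compound 3 is a 12-fold higher number from compound 2 to compound 3 (1.09 log units; beyond the scatter), toward a higher number. Compound 3 is therefore expected to give about 300 nM in this assay, within 25 nM to 6000 nM.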

Compound 3, half-maximal inhibitory concentration in the C-X-C chemokine receptor type 4 assay: 24.2 nM
For compound 3 the middle estimate is 12-fold (1.09 log units) above the measured one; measured number below the stated range.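

In the C-X-C chemokine receptor type 4 assay, compound 2 gives 24.6 nM and compound 3 gives 24.2 nM, a 1.0-fold lower number from compound 2 to compound 3 (0.01 log units; within the scatter), so this position on the saturated chain carbon bound to an amine nitrogen accepts a much larger group than 3-amino-3-methylbutyl, one with a six-membered non-aromatic ring and a double bond, with no step beyond the scatter. In a physicochemical assay for permeability, using PAMPA, with a stated time of 4 h, at pH 5.5, tested at 100 uM (a higher number here means that the compound crosses the layer faster, a lower number that the compound crosses the layer more slowly), compound 2 gives 20 nm/s and compound 3 gives 33.5 nm/s, a 1.7-fold higher number from compound 2 to compound 3 (0.22 log units; within the scatter), so the same exchange also stays within the scatter in the physicochemical assay. Back in the C-X-C chemokine receptor type 4 assay, a further reading, an at least 1300-fold lower number from compound 1 to compound 3 (3.13 log units; beyond the scatter), rests on a limit of the assay and not a number, and so is a bound only: the limit of > 33300 nM in the C-X-C chemokine receptor type 4 assay, at which 1 of the 3 values shown sits.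

The double bond and the six-membered ring with its hetero atom enter together, so the compounds shown do not tell which of them, if either, matters for the read-out; a saturated chain in place of the double bond, or a cyclohexyl ring in place of the ring with the oxygen, would separate the two. Also open, from the compounds shown here alone, is how far the position tolerates change in the chain nitrogen itself, for example an amide or a carboxylic acid in place of the amine.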